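A Nitro Group Added to the Phenyl Ring of Compound 2

This account rests on a few compounds, and the source may have more. Where it says the series, first, only, none or still open, it means among the compounds named here.

Compound 2 `O=C(N1CCC=C[C@@H]1COCc1ccccc1)n1cc(-c2ccccc2)nn1` was tested in an assay on HEK293 cells for inhibition of Monoacylglycerol lipase ABHD6 (Homo sapiens), read by fluorescence (on this read-out higher numbers stand for weaker inhibition and lower numbers for stronger inhibition), where compound 2 gives 158 nM. Among the two compounds measured so far it stands at the weaker end: compound 1 `O=C(N1CCCC[C@@H]1COCc1ccccc1)n1cc(-c2ccc(-c3ccccc3)cc2)nn1` gives 3.16 nM in this assay, a far lower number, and the gap between the two lies well beyond the usual scatter of repeated measurements. Compound 1 differs from compound 2 in more than one place, so these two values show only how far apart the two molecules end up, not which part of the difference matters.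

Compound 3 `O=C(N1CCC=C[C@@H]1COCc1ccccc1)n1cc(-c2ccc([N+](=O)[O-])cc2)nn1` has not been measured yet. It differs from compound 2 in one place: nitro in place of hydrogen on an aromatic carbon. Within the data shown here, no measured pair isolates this change, so its effect can only be guessed. The step from compound 2 to compound 3 is expected to be a modest move toward a lower number, at the edge of the scatter, because compound 1 carries a larger phenyl ring and still gives 3.16 nM. Compound 3 is therefore estimated at 70 nM, with a range from 15 nM to 300 nM, which corresponds to an expected step of a 2.3-fold lower number from compound 2 to compound 3 (0.35 log units; beyond the scatter).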

Compound 3, half-maximal inhibitory concentration: 31.6 nM
The estimate for compound 3 lay 2.2-fold (0.35 log units) above the measured number; measured number inside the range.
By their numbers in this assay, from the lowest: compound 1; then compound 3; then compound 2.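

In this assay, the change from phenyl to 4-nitrophenyl gives a 5.0-fold lower number from compound 2 to compound 3 (0.70 log units; beyond the scatter), the first effect in this series that can be traced to a single place in the molecule. It shows that this aromatic carbon, para to a large group, can carry a group of 3 heavy atoms instead of hydrogen, and that the inhibition gets stronger rather than weaker. Nothing measured here explains why nitro has this effect, so the result records what happens and gives no mechanism.

The compounds shown leave open whether the gain is specific to nitro or would also appear with another group at this place, such as an amine, a carboxylic acid or a longer chain like an ethyl group. They also leave open whether the same change would give a similar step on the core of compound 1, since compound 1 differs from compound 3 in more than one place and cannot show what any single difference contributes.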